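The source may report more compounds than this note shows. Statements on the series, on what has been measured and on what is new or still open speak of the compounds shown alone.

Series notes. Compound 1 `CC(C)NC(=O)N1CCN(C(=S)SCc2cn(Cc3ccccc3F)nn2)CC1` and compound 2 `CC(C)(C)NC(=O)N1CCN(C(=S)SCc2cn(Cc3ccccc3F)nn2)CC1` share one core; in a functional assay on MCF7 cells (Homo sapiens) for cytotoxicity, read by MTT assay, with a stated time of 72 h (a higher number here means a weaker inhibitor, a lower number a stronger inhibitor), compound 1 gives 1860 nM and compound 2 gives 18800 nM. The change between them is methyl in place of hydrogen on a saturated chain carbon bound to an amide-type nitrogen and two saturated chain carbons, and it made a 10-fold higher number from compound 1 to compound 2 (1.00 log units; beyond the scatter). Compound 3 `CCNC(=O)N1CCN(C(=S)SCc2cn(Cc3ccc(OC)cc3)nn2)CC1` sits on another core; the difference between the two cores is not broken down here. In this assay compound 3 gives 97600 nM, the highest number among the three measured. Compound 4 `COc1ccc(Cn2cc(CSC(=S)N3CCN(C(=O)NC(C)C)CC3)nn2)cc1` awaits measurement; it differs from compound 3 by methyl in place of hydrogen on a saturated chain carbon bound to an amide-type nitrogen and a saturated chain carbon. Among the compounds with values here, this is the same kind of change as the one from compound 1 to compound 2, not the same: there the carbon receiving the methyl is bound to an amide-type nitrogen and two saturated chain carbons, here to an amide-type nitrogen and a saturated chain carbon. Within the data shown here, only one step of this kind is known, made on the other core, so the expectation for compound 4 rests on a 10-fold higher number from compound 1 to compound 2 (1.00 log units; beyond the scatter) and on compound 3 already standing at 97600 nM. Compound 4 is expected to give about 90000 nM, estimated to lie between 15000 nM and 450000 nM. That step is expected to be a 1.1-fold lower number from compound 3 to compound 4 (0.04 log units; within the scatter) in this assay.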

Compound 4, half-maximal inhibitory concentration: 19600 nM
For compound 4 the middle estimate is 4.6-fold (0.66 log units) above the measured one; the measured number falls inside the stated range.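

In this assay the methyl step does not carry from one core to the other, and its direction reverses: the same change on two cores in this assay, a 10-fold higher number (1.00 log units; beyond the scatter) from compound 1 to compound 2 and a 5.0-fold lower number (0.70 log units; beyond the scatter) from compound 3 to compound 4, 50-fold (1.70 log units) apart, beyond the scatter of two such steps.

Ethyl to isopropyl gives a 5.0-fold lower number from compound 3 to compound 4 (0.70 log units; beyond the scatter), and with the isopropylcarbamoyl end held constant, 4-methoxyphenyl in place of 2-fluorophenyl gives an 11-fold higher number from compound 1 to compound 4 (1.02 log units; beyond the scatter), so the aryl group also moves the number in this series. The two methyl steps are not strictly alike: the carbon receiving the methyl is bound to an amide-type nitrogen and two saturated chain carbons in one, and to an amide-type nitrogen and a saturated chain carbon in the other. The pair therefore shows that the step's direction on one core gave no guide to the other, but not whether the core or the carbon receiving the methyl lies behind the reversal.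

The compounds shown leave open how ethylcarbamoyl behaves with 2-fluorophenyl, which would separate these two readings. Also open, on these data alone, is whether a longer chain, such as butyl, or a cyclohexyl group on the carbamoyl nitrogen follows either trend.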